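The compounds below may be only part of what the source reports. "The series", "measured", "known", "first", "only" and "open" are said of these compounds alone.

Compound 1, `O=C(NCc1ccc(F)cc1)c1nc(NCCO)c2cccnc2c1O`, was tested in a toxicity assay on C8166 cells (Homo sapiens) for cytotoxicity, read by MTT assay, with a stated time of 72 h; on this read-out lower numbers stand for higher toxicity in this test and higher numbers for lower toxicity in this test. In this assay compound 1 gives 91000 nM.
Compound 2, `C[C@@H](Nc1c(C(=O)NCc2ccc(F)cc2)nc(Br)c2cccnc12)c1ccccc1`: in this assay compound 2 gives "not determined" (no result reported).
Compound 3, `NCCCNc1c(C(=O)NCc2ccc(F)cc2)nc(Br)c2cccnc12`: in this assay compound 3 gives "not determined" (no result reported).

Compound 2 stands on no number in this assay; nothing was reported for it, and the same holds for compound 3. Compound 4, `O=C(NCc1ccc(F)cc1)c1nc(Br)c2cccnc2c1NCCO`, is still to be measured in this assay. It differs from compound 2 in one place: 2-hydroxyethyl in place of 1-phenylethyl on a nitrogen on an aromatic ring. Among the measured compounds shown here, no measured step between these compounds exists, and compound 2 itself has no value, so neither size nor direction can be read from the data; nothing points to a move beyond the usual scatter. For the measured compounds named here, the only measured guide is compound 1 at 91000 nM. Compound 4 is expected to fall near that, at an estimated 80000 nM, with a range of 30000 nM to 200000 nM.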

Compound 4, half-maximal cytotoxic concentration: 232000 nM
Beside the measured number, compound 4's estimate is 2.9-fold (0.46 log units) below it; measured number outside the range, above it.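

No step can be read between compound 2 and compound 4, as compound 2 has no number to set against compound 4. No supporting evidence bears on this result. As far as these compounds go, whether (2-hydroxyethyl)amino in place of (1-phenylethyl)amino raises or lowers the number remains open.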